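From compound 1 to compound 4: an oxan-4-yl addition

A few compounds are considered here, and "the series" means these few. Any claim that something is new, unique, unknown or untested is made for them only; others in the source may bear on it.

Compound 1 `CCN1CCN(c2nc(C)nc3c2nc(-c2ccccc2Cl)n3C)CC1`: 30%
Compound 2 `CC(=O)NCCn1c(-c2ccccc2Cl)nc2c(N3CCN(C)CC3)nc(C)nc21`: 0%
Compound 3 `Cc1nc(N2CCN(C)CC2)c2nc(-c3ccccc3Cl)n(CCN3CCCC3=O)c2n1`: 28%

In an ADME assay (liver) for metabolic stability, with Liver microsome (Rattus norvegicus) as the target, read by LC-MS, using microsomes, with a stated time of 30 min, tested at 4 uM (a higher number here means that more of the compound is left, a lower number that less of the compound is left), compound 1 gives 30%, level within the scatter with compound 3 and clearly apart from compound 2. Compound 4 `CCN1CCN(c2nc(C)nc3c2nc(-c2ccccc2Cl)n3CC2CCOCC2)CC1` differs from compound 1 by oxan-4-yl in place of hydrogen on a saturated chain carbon bound to an aromatic nitrogen, with oxan-4-yl in place of hydrogen on a saturated chain carbon bound to an aromatic nitrogen. Among the measured compounds shown here, no measured step makes this exact change. The nearest is a number 28 percentage points higher from compound 2 to compound 3 (beyond the scatter), which shows that a change on such a chain can move the number beyond the scatter. Compound 2 and compound 3 also carry larger groups on that chain, though they differ elsewhere too, and neither stands clearly above compound 1. A modest fall is therefore expected, and the expected step is a number 15 percentage points lower from compound 1 to compound 4 (beyond the scatter). For compound 4 the estimated value is 15%, with an expected range from 2% to 35%.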

Compound 4, percent of the compound remaining in the Liver microsome assay: 80%
Estimate against measurement, compound 4: 65 percentage points below; measured number above the stated range.
By their numbers in the Liver microsome assay, from the lowest: compound 2; then compounds 3 and 1 (each within the scatter of the next); then compound 4.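

In the Liver microsome assay compound 1 gives 30% and compound 4 gives 80% with oxan-4-yl in place of hydrogen on a saturated chain carbon bound to an aromatic nitrogen, which is a number 50 percentage points higher from compound 1 to compound 4 (beyond the scatter), so a larger group at this position need not lower the number. In a physicochemical assay for lipophilicity (on this read-out higher numbers stand for higher lipophilicity and lower numbers for lower lipophilicity), compound 1 gives 3.1 and compound 4 gives 3.4 with the same change giving a number 0.30 log units higher from compound 1 to compound 4 (within the scatter), which leaves the two compounds level on that read-out. Nothing measured here accounts for the rise.

The compounds shown leave open whether the ring oxygen or simply the size of the group goes with the rise. A cyclohexyl group or a longer alkyl chain in the same place would tell these apart.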